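Furan-3-yl in place of 4-chlorophenyl on a shared core

A few compounds are considered here, and "the series" means these few. Any claim that something is new, unique, unknown or untested is made for them only; others in the source may bear on it.

Compound 1 `Nc1ncnn2c([C@@H]3O[C@H](CO)[C@@H](O)[C@H]3O)cc(C#Cc3ccccc3)c12`: 37700 nM
Compound 2 `Nc1ncnn2c([C@@H]3O[C@H](CO)[C@@H](O)[C@H]3O)cc(-c3ccc(Cl)cc3)c12`: 56700 nM

In a functional assay on CAPAN-1 cells (Homo sapiens) for antiproliferative activity, with a stated time of 72 h (a lower number here means a stronger inhibitor, a higher number a weaker inhibitor), compound 2 gives 56700 nM, and compound 1 gives 37700 nM; the two numbers lie within the scatter of each other. Compound 3 `Nc1ncnn2c([C@@H]3O[C@H](CO)[C@@H](O)[C@H]3O)cc(-c3ccoc3)c12` is not yet measured. Its change from compound 2 is furan-3-yl in place of 4-chlorophenyl on an aromatic carbon. Going by the values given here, the only measured step, a 1.5-fold higher number from compound 1 to compound 2 (0.18 log units; within the scatter), exchanges the whole group on the same aromatic carbon and stays within the scatter, and no measured pair replaces a six-membered ring by a five-membered one. No step beyond the scatter is therefore expected, as a 1.1-fold higher number from compound 2 to compound 3 (0.02 log units; within the scatter). For compound 3 the expected value in this assay is 60000 nM, with a range from 20000 nM to 180000 nM.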

Compound 3, half-maximal inhibitory concentration: 900 nM
Beside the measured number, compound 3's estimate is 67-fold (1.82 log units) above it; measured number outside the range, below it.
By their numbers in this assay, from the lowest: compound 3; then compounds 1 and 2 (each within the scatter of the next).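

In this assay this aromatic carbon proves sensitive to the group it carries: furan-3-yl in place of 4-chlorophenyl gives a 63-fold lower number from compound 2 to compound 3 (1.80 log units; beyond the scatter) and furan-3-yl in place of 2-phenylethynyl gives a 42-fold lower number from compound 1 to compound 3 (1.62 log units; beyond the scatter) on the same shared core. Compounds 1 and 2 alone had shown no change beyond the scatter at this position, so the sensitivity appears only with the five-membered aromatic ring. Going by these compounds, whether it depends on the ring size or on the ring oxygen stays open, and thiophen-3-yl or plain phenyl would separate the two. Nothing given here explains the gain.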